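A Pyridyl Group Replaces the Thienyl Ketone of Compound 1

The source may report more compounds than this note shows. Statements on the series, on what has been measured and on what is new or still open speak of the compounds shown alone.

Of the compounds shown here, three sharing one core have been measured in a functional assay (trachea) with Rattus norvegicus as the target; a lower number here means a less potent compound, a higher number a more potent compound, by a factor of ten per unit of this negative logarithm. Compound 1 `CC1(C)C=C(n2ccccc2=O)c2cc(C(=O)c3cccs3)ccc2O1` gives 5.84 and stands highest of the three; its nearest neighbour is compound 3 `CC1(C)C=C(n2ccccc2=O)c2cc(OC(=O)Nc3ccccc3C(F)(F)F)ccc2O1`, which gives 5.19, and the furthest is compound 2 `CC1(C)C=C(n2ccccc2=O)c2cc(OC(=O)Nc3ccccc3F)ccc2O1`, which gives 4.22. Going by the values given here, the only single-point step among them, a number 0.97 log units higher from compound 2 to compound 3 (beyond the scatter), concerns the carbamate series and not the ketone of compound 1.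

Compound 4 `CC1(C)C=C(n2ccccc2=O)c2cc(-c3ccncc3)ccc2O1` is not yet measured. It differs from compound 1 in one place: pyridin-4-yl in place of (thiophen-2-yl)carbonyl on an aromatic carbon. Among the compounds with values here, no measured step bears on this exchange, and the carbamate step offers no guide to it, so the size of the change in this assay cannot be read from the data; only the spread of the three values suggests where compound 4 may fall. A modest decrease from compound 1 is expected, giving a number 0.54 log units lower from compound 1 to compound 4 (beyond the scatter) as the estimated step. Compound 4 is therefore estimated at 5.3, within a range from 4.5 to 6.1.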

Compound 4, logarithm of the reciprocal of the active concentration, log(1/C): 6.32
Estimate against measurement, compound 4: 1.02 log units below, and the stated range ends below it.
By their numbers in this assay, from the lowest: compound 2; then compound 3; then compound 1; then compound 4.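

In this assay, the step to pyridin-4-yl reads as a number 0.48 log units higher from compound 1 to compound 4 (beyond the scatter), so this aromatic carbon of the shared core can carry a six-membered aromatic ring in place of (thiophen-2-yl)carbonyl without any loss. Until now every group at this carbon held a carbonyl, and compound 4 shows that a carbonyl is not required there for a high number. Nothing measured here accounts for the size or direction of this step.

The compounds shown leave open whether the ring nitrogen of pyridin-4-yl matters, or whether a phenyl, a pyridin-3-yl or a directly attached thiophen-2-yl group would read the same. They also leave open how an amine or a carboxylic acid on the pyridine ring would change the number.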